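The compounds below may be only part of what the source reports. "The series", "measured", "known", "first", "only" and "open" are said of these compounds alone.

Measured compounds:
compound 1, `O=C(NCc1cn(Cc2ccc(F)cc2)nn1)c1cn(-c2ccccc2)nc1-c1ccccc1`: 9600 nM
compound 2, `O=C(NCc1cn(Cc2ccc(Cl)cc2)nn1)c1cn(-c2ccccc2)nc1-c1ccc(F)cc1`: 280 nM

Both were run in a functional assay on MIA PaCa-2 cells (Homo sapiens) for antiproliferative activity, read by sulforhodamine B assay, with a stated time of 48 h; a higher number here means a weaker inhibitor of growth, a lower number a stronger inhibitor of growth. In this assay compound 1 gives 9600 nM, and compound 2 gives 280 nM. Compound 2 therefore holds the lower of the two numbers, and the gap to compound 1 lies beyond the scatter. Among the compounds with values here, compounds 1 and 2 differ from each other in two places at once, so no single step connects them and the two values say nothing about either change taken on its own.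

Compound 3, `COc1cc(Cn2cc(CNC(=O)c3cn(-c4ccccc4)nc3-c3ccc(F)cc3)nn2)cc(OC)c1OC`, has not yet been measured. It differs from compound 2 in one place: 3,4,5-trimethoxyphenyl in place of 4-chlorophenyl on a saturated chain carbon bound to an aromatic nitrogen. Within the data shown here, no measured pair carries that change, so there is nothing to read its effect from. The working expectation is a step from compound 2 to compound 3 that raises the number somewhat, of a size that may or may not clear the scatter, a 2.1-fold higher number from compound 2 to compound 3 (0.33 log units; beyond the scatter). For compound 3 in this assay the estimate is 600 nM, with a range from 150 nM to 3000 nM.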

Compound 3, concentration for 50% growth inhibition: 5200 nM
Beside the measured number, compound 3's estimate is 8.7-fold (0.94 log units) below it, outside the stated range (above it).
By their numbers in this assay, from the lowest: compound 2; then compounds 3 and 1 (each within the scatter of the next).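

In this assay, within the data shown here, putting 3,4,5-trimethoxyphenyl in place of 4-chlorophenyl on a saturated chain carbon bound to an aromatic nitrogen gives a 19-fold higher number from compound 2 to compound 3 (1.27 log units; beyond the scatter), the only single-place step so far, and it shows that the number responds strongly to the group at this position. This step does not isolate one feature: the entering group has 12 heavy atoms against 7 and 3 hydrogen-bond acceptors against 0, and the chlorine leaves in the same change, so the step cannot be assigned to any one of these differences. No measurement at hand accounts for the rise.

Open, going by these compounds, is how a 4-methoxyphenyl, a 3,5-dimethoxyphenyl or a 4-aminophenyl would stand at this position, which would show whether the rise tracks the number of methoxy groups, the place of one of them or the loss of the chlorine. Also open, on these data alone, is the effect of 4-fluorophenyl against 4-chlorophenyl here, since compound 1 and compound 2 differ in two places at once.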